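The compounds below may be only part of what the source reports. "The series", "measured", "known", "first", "only" and "open" are said of these compounds alone.

Working notes on the series, measured in a functional assay on HaCaT cells (Homo sapiens) for inhibition, read by sulforhodamine B assay, with a stated time of 48 h; on this read-out higher numbers stand for weaker inhibition of growth and lower numbers for stronger inhibition of growth:

- compound 1 `COc1ccc(/C=C/C2(C)C=CC(=O)O2)c(OC)c1`: 53600 nM
- compound 2 `COc1ccc(/C=C/C2(C)C=CC(=O)O2)cc1OC`: 838000 nM

Compound 2 holds the higher of the two numbers, and the gap down to compound 1 lies beyond the scatter. Two values alone establish no trend.

The next compound is compound 3 `COc1cc(OC)c(OC)cc1/C=C/C1(C)C=CC(=O)O1`. It follows from compound 2 by methoxy in place of hydrogen on an aromatic carbon, ortho to a group of 9 heavy atoms: methoxy in place of hydrogen on an aromatic carbon. Within the data shown here, no measured pair isolates this change, so the expectation rests on one comparison. The structure of compound 1 also carries a methoxy in that place, and compound 1 gives 53600 nM, so compound 3 is expected to move toward that lower number. Among the measured compounds shown here, the additional methoxy has no measured counterpart, which keeps the range wide. The expected step, a 7.0-fold lower number from compound 2 to compound 3 (0.84 log units; beyond the scatter), points to stronger inhibition of growth and is estimated to lie beyond the scatter. For compound 3 the estimated value is 120000 nM, with an expected range from 30000 nM to 500000 nM.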

Compound 3, concentration for total growth inhibition: 180000 nM
Compound 3: the middle estimate sits 1.5-fold (0.18 log units) below what was measured; the range from low to high includes it.
By their numbers in this assay, from the lowest: compound 1; then compound 3; then compound 2.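

In this assay methoxy in place of hydrogen on an aromatic carbon, ortho to a group of 9 heavy atoms, now has a measured effect on compound 2: the change gives a modest move toward stronger inhibition of growth (a 4.7-fold lower number from compound 2 to compound 3 (0.67 log units; beyond the scatter)). Reached from compound 1, the same kind of change runs the other way, toward weaker inhibition of growth (a 3.4-fold higher number from compound 1 to compound 3 (0.53 log units; beyond the scatter)), so across these compounds methoxy in place of hydrogen on an aromatic carbon has no single direction, and the outcome differs with the compound that receives it. No measurement at hand accounts for this difference in direction.

The compounds shown leave open whether a group other than methoxy in that place, such as a hydroxyl, a fluorine or an amine, would move the number in the same direction as methoxy does from compound 2. Also open is how the number responds when the methyl on the shared core gives way to a longer chain, as that methyl stays constant across all the compounds shown.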